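Swapping a hydroxymethyl for a methoxy on the side chain

The source may report more compounds than this note shows. Statements on the series, on what has been measured and on what is new or still open speak of the compounds shown alone.

Three compounds share one core and differ only in the chain attached to a saturated ring carbon. Compound 1 `CNC(=O)C[C@@H]1C[C@@H](c2ccc(Cl)c(Cl)c2)[C@H](NC(=O)c2cc(-c3c(Cl)cnn3C)c(Cl)o2)CN1` carries a methylcarbamoyl there; in an assay for inhibition of RAC-alpha serine/threonine-protein kinase (Homo sapiens), read by HTRF, with a stated time of 1 h (on this read-out lower numbers stand for stronger inhibition and higher numbers for weaker inhibition), compound 1 gives 2.64 nM. Compound 2 `Cn1ncc(Cl)c1-c1cc(C(=O)N[C@@H]2CN[C@H](CCCO)C[C@H]2c2ccc(Cl)c(Cl)c2)oc1Cl` carries a 3-hydroxypropyl instead, and in this assay compound 2 gives 2.56 nM. Compound 3 `CC(=O)NCC[C@@H]1C[C@@H](c2ccc(F)c(F)c2)[C@H](NC(=O)c2cc(-c3c(Cl)cnn3C)c(Cl)o2)CN1` has a different ring substitution and a different chain, and in this assay compound 3 gives 2.49 nM. Compound 2 sits in the middle of these three numbers, and all three lie within the usual scatter of one another.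

Compound 4 `COCC[C@@H]1C[C@@H](c2ccc(Cl)c(Cl)c2)[C@H](NC(=O)c2cc(-c3c(Cl)cnn3C)c(Cl)o2)CN1` is built from compound 2 by methoxy in place of hydroxymethyl on a saturated chain carbon, two bonds along the chain from a saturated ring carbon. For the measured compounds named here, the one measured step at the chain, a 1.0-fold lower number from compound 1 to compound 2 (0.01 log units; within the scatter), shows that a large change of the chain end left the number where it was. The change from compound 2 to compound 4 is smaller, so the step of a 1.1-fold higher number from compound 2 to compound 4 (0.02 log units; within the scatter) is expected to stay within the scatter. Compound 4 is therefore estimated at 2.7 nM, in the range 1.3 nM to 5.5 nM.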

Compound 4, half-maximal inhibitory concentration: 7.01 nM
The estimate for compound 4 lay 2.6-fold (0.41 log units) below the measured number; the whole stated range lies below it.
By their numbers in this assay, from the lowest: compounds 3, 2 and 1 (each within the scatter of the next); then compound 4.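

In this assay, for the compounds shown here, the end of this chain is not as indifferent as the earlier compounds suggested: a 2.7-fold higher number from compound 2 to compound 4 (0.44 log units; beyond the scatter), an exchange that keeps the count of heavy atoms and gives up only the hydrogen-bond donor of the hydroxymethyl. The step of a 2.7-fold higher number from compound 1 to compound 4 (0.42 log units; beyond the scatter) is of similar size, so compound 1 and compound 2, which lie within the scatter of each other, both stand apart from compound 4. Nothing available explains the step.

On these data alone, whether losing the donor is what matters remains open, since one exchange cannot separate that from any other difference between the two chain ends. A primary amine at the chain end, or a longer chain ending in hydroxyl, would show how far this sensitivity extends.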